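The compounds below may be only part of what the source reports. "The series", "measured", "known", "first", "only" and "open" are said of these compounds alone.

Compound 1 `Clc1ccc(Nc2ncccn2)cc1Oc1ccccc1` gives 30000 nM in an ADME assay on MT2 cells (Homo sapiens) for cytotoxicity; a higher number here means that more compound is tolerated, a lower number that less compound is tolerated. For the measured compounds named here, compound 2 `COc1ccnc(Nc2ccc(Cl)c(Oc3ccccc3)c2)n1` gives 38000 nM in this assay, the only other number; the step of a 1.3-fold higher number from compound 1 to compound 2 (0.10 log units; within the scatter) lies within the scatter, so compound 2 and compound 1 cannot be told apart on these numbers. Compound 3 `COc1ccnc(Nc2ccc(Cl)c(Sc3ccccc3)c2)n1` differs from compound 2 by phenylsulfanyl in place of phenoxy on an aromatic carbon. Going by the values given here, no measured step exchanges phenoxy for phenylsulfanyl, and the single measured step of a 1.3-fold higher number from compound 1 to compound 2 (0.10 log units; within the scatter) concerns a different change and is within the scatter, so nothing here points to a step beyond the scatter in this assay. The step expected is no change at the digits printed from compound 2 to compound 3 (within the scatter). Compound 3 is estimated at 38000 nM, with a range from 15000 nM to 95000 nM.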

Compound 3, half-maximal cytotoxic concentration: 21000 nM
Estimate against measurement, compound 3: 1.8-fold (0.26 log units) above, and the stated range covers the measured number.
By their numbers in this assay, from the lowest: compounds 3, 1 and 2 (each within the scatter of the next).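

On the aromatic carbon ortho to a chloro group, phenylsulfanyl in place of phenoxy gives a 1.8-fold lower number from compound 2 to compound 3 (0.26 log units; within the scatter) in this assay and so leaves compound 3 and compound 2 indistinguishable. For the compounds shown here, this is the first reading at this position, and the exchange of one ring-bearing group for the other shows no step beyond the scatter. No available data bear on the size of this step.

From the compounds shown here alone, whether an amine, a carboxylic acid or a longer chain at this carbon would give a step beyond the scatter remains open. Also open, going by these compounds, is whether the methoxy step would read the same with phenylsulfanyl in place.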